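One Added Methoxy Group on Compound 2

This account rests on a few compounds, and the source may have more. Where it says the series, first, only, none or still open, it means among the compounds named here.

Of the compounds shown here, two have been measured so far. In a functional assay on Jurkat cells (Homo sapiens) for inhibition, read by MTT assay, with a stated time of 72 h (a higher number here means a weaker inhibitor, a lower number a stronger inhibitor), compound 1 (`COc1cccc(/C=C/C(=O)Nc2cc(OC)c(OC)c(OC)c2)c1`) gives 12500 nM as its half-maximal inhibitory concentration, while compound 2 (`C=C(Br)C(=O)Nc1cccc(/C=C/C(=O)Nc2cc(OC)cc(OC)c2)c1`) gives 980 nM on the same read-out. Compound 2 therefore holds the lower of the two numbers, and the gap between them lies beyond the usual scatter.

The next compound, compound 3 (`C=C(Br)C(=O)Nc1cccc(/C=C/C(=O)Nc2cc(OC)c(OC)c(OC)c2)c1`), differs from compound 2 in one place: methoxy in place of hydrogen on an aromatic carbon with methoxy in place of hydrogen on an aromatic carbon. The new group sits ortho to two methoxy groups and para to a large group. Going by the values given here, no measured pair shows what this change does in this assay, so the expectation starts from compound 2 at 980 nM alone. Only a small shift toward a lower number is expected, and it may not exceed the scatter. The estimated change is a 1.4-fold lower number from compound 2 to compound 3 (0.15 log units; within the scatter) in this reading. Compound 3 is expected at 700 nM with an estimated range from 200 nM to 2200 nM across repeated measurements.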

Compound 3, half-maximal inhibitory concentration: 290 nM
For compound 3 the middle estimate is 2.4-fold (0.38 log units) above the measured one; the range from low to high includes it.
By their numbers in this assay, from the lowest: compound 3; then compound 2; then compound 1.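

In this assay the position ortho to two methoxy groups and para to a large group turns out to respond to substitution: methoxy in place of hydrogen on this aromatic carbon gives a 3.4-fold lower number from compound 2 to compound 3 (0.53 log units; beyond the scatter) and so exceeds the scatter, which neither earlier compound could show, as they did not differ in one place. Compound 3 also links the series to compound 1, since ((1-bromoethenyl)carbonyl)amino in place of methoxy on an aromatic carbon gives a 43-fold lower number from compound 1 to compound 3 (1.63 log units; beyond the scatter) on the same trimethoxy-bearing side, a step rated large where the added methoxy step is rated modest. Nothing beyond these cell numbers is available to account for either step.

What the compounds shown leave open is whether this position is specific to methoxy, as an ethoxy group, a hydroxyl group or a single fluorine atom there could give a quite different number. As far as these compounds go, it also remains open whether the gain from the added methoxy holds when the ((1-bromoethenyl)carbonyl)amino group is replaced, for example by an acetylamino group lacking the bromine atom.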